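A Second Chlorine on the Shared Core of Compound 1

The source may hold more compounds than are shown below. What is called first, only, known or untested is meant among the compounds shown, and "the series" means these compounds.

Compound 1 `ClCc1cccc(Cn2cnc3ncnc(Cl)c32)c1` is one of three compounds with a shared core that have been tested in a functional assay on MDA-MB-231 cells (Homo sapiens) for cytotoxicity, read by sulforhodamine B assay, with a stated time of 48 h; a lower number here means a stronger inhibitor of growth, a higher number a weaker inhibitor of growth. Compound 1 gives 3380 nM. Compound 2 `ClCc1cccc(Cn2cnc3c(Cl)nc(Cl)nc32)c1` gives 3710 nM, and compound 3 `ClCc1ccc(Cn2cnc3c(Cl)nc(Cl)nc32)cc1` gives 3630 nM. Compound 1 therefore holds the lowest of the three numbers, but the values of compound 3 and compound 2 both lie within the usual scatter of it, so the three cannot be told apart on these data.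

Compound 4 `ClCc1cccc(Cn2cnc3nc(Cl)nc(Cl)c32)c1` has not yet been measured. It differs from compound 1 by chloro in place of hydrogen on an aromatic carbon, between two ring nitrogen atoms, meta to a chloro group, meta to a fused ring and para to a fused ring.

For the measured compounds named here, no measured pair shows exactly this step. Compounds 2 and 3, whose cores likewise carry an added chloro group, sit within the scatter of compound 1, which gives no sign that such a change moves the number much. The step of a 1.0-fold higher number from compound 1 to compound 4 (0.02 log units; within the scatter) is expected to be small, in no clear direction and not beyond the scatter. Compound 4 is estimated at 3500 nM, within a range from 1700 nM to 7200 nM.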

Compound 4, concentration for total growth inhibition: 1730 nM
The estimate for compound 4 lay 2.0-fold (0.31 log units) above the measured number, and the stated range covers the measured number.
By their numbers in this assay, from the lowest: compounds 4, 1, 3 and 2 (each within the scatter of the next, the first and the last beyond it).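

For the compounds shown here, compound 4 gives the first direct reading of chloro in place of hydrogen on an aromatic carbon, here between two ring nitrogen atoms: in this assay there is a 2.0-fold lower number from compound 1 to compound 4 (0.29 log units; within the scatter) at this position. The step shows that this carbon can carry a chloro group with no loss of growth inhibition that these data can detect, but it is too small to count as a gain. Nothing available here bears on what lies behind this result.

What the compounds shown leave open is whether this position accepts larger or different groups as well: an amine, a methoxy group or a longer chain could give quite another number. Fluoro and bromo at the same carbon would show whether chloro itself matters here.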